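Nitro in place of hydrogen on compound 1

The source may report more compounds than this note shows. Statements on the series, on what has been measured and on what is new or still open speak of the compounds shown alone.

In an ADME assay on CNE-2 cells (Homo sapiens) for cytotoxicity, read by MTT assay, with a stated time of 48 h (on this read-out higher numbers stand for weaker inhibition and lower numbers for stronger inhibition), compound 1 `COc1ccc(-c2cn(Cc3ccc(C(C)(C)C)cc3)nn2)cc1` gives 4000 nM. Compound 2 `CC(C)(C)c1ccc(Cn2cc(-c3ccc(O)cc3)nn2)cc1` gives 5600 nM, and compound 3 `CC(C)(C)c1ccc(Cn2cc(-c3cc(O)c(O)c(O)c3)nn2)cc1` gives 40 nM. Compound 1 thus stands at the high end of these numbers together with compound 2, well above compound 3. Compound 4 `COc1ccc(-c2cn(Cc3ccc(C(C)(C)C)cc3)nn2)c([N+](=O)[O-])c1` follows from compound 1 through (nitro in place of hydrogen on an aromatic carbon). Going by the values given here, the only measured single-place step, a 1.4-fold higher number from compound 1 to compound 2 (0.15 log units; within the scatter), stays within the scatter and adds no nitro. Among the compounds with values here, no measured compound carries nitro, so the direction is open and no step beyond the scatter is expected. The estimated step is no change at the digits printed from compound 1 to compound 4 (within the scatter). For compound 4 the expected value is 4000 nM, with an estimated range of 1500 nM to 11000 nM.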

Compound 4, half-maximal inhibitory concentration: 1600 nM
Estimate against measurement, compound 4: 2.5-fold (0.40 log units) above, within the range that was stated.
By their numbers in this assay, from the lowest: compound 3; then compound 4; then compounds 1 and 2 (each within the scatter of the next).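

In this assay, nitro in place of hydrogen on this aromatic carbon, ortho to a large group and meta to a methoxy group, gives a 2.5-fold lower number from compound 1 to compound 4 (0.40 log units; beyond the scatter). This carbon is therefore a place where a single change moves the number modestly beyond the scatter, and the move is toward stronger inhibition. Nothing measured here gives a reason for the step.

Going by these compounds, whether an amine or a carboxylic acid on this same carbon moves the number in the same direction remains open. So does whether nitro has a similar effect on compound 2 or compound 3.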